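Cytotoxicity Outlook for a 4-Phenylphenyl Analogue

The source may hold more compounds than are shown below. What is called first, only, known or untested is meant among the compounds shown, and "the series" means these compounds.

Compound 1, `COC(=O)c1ccc(NCc2cncn2Cc2ccccc2Cl)cc1-c1ccccc1`: 10000 nM
Compound 2, `COC(=O)c1ccc(NCc2cncn2Cc2cccc(F)c2)cc1-c1ccccc1`: > 1000 nM, a limit

In a toxicity assay on NIH3T3 cells (Mus musculus) for cytotoxicity, read by resazurin assay (a lower number here means that less compound is needed, a higher number that more compound is needed for the effect), compound 1 gives 10000 nM. For compound 2 the assay returns only a limit, > 1000 nM, as the limit of > 1000 nM in this assay, at which 1 of the 2 values shown sits, records. The step that the limit leaves unreadable from compound 1 to compound 2 therefore cannot be sized. Compound 3, `COC(=O)c1ccc(NCc2cncn2Cc2ccc(-c3ccccc3)cc2)cc1-c1ccccc1`, is yet to be measured; it differs from compound 2 by 4-phenylphenyl in place of 3-fluorophenyl on a saturated chain carbon bound to an aromatic nitrogen. For the measured compounds named here, no measured step bears on this change, and compound 2 itself stands only at a limit, so no direction beyond the scatter is expected. Compound 3 is estimated at 8000 nM, with a range from 2000 nM to 30000 nM. That estimate corresponds to an expected step that the limit leaves unreadable from compound 2 to compound 3.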

Compound 3, half-maximal effective concentration: > 1000 nM
Compound 3: only a limit was reported; the forecaster's own chance of this, stated with the estimate: 40%; the middle value lies beyond the limit too.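

In this assay compound 3 gives only a limit (> 1000 nM). No new step can be read from compound 3 to compound 1 or compound 2, since this result sits at the same limit as compound 2: the limit of > 1000 nM in this assay, at which 2 of the 3 values shown sit.

The compounds shown leave open where compound 2 and compound 3 truly stand, and whether 4-phenylphenyl and 3-fluorophenyl differ at all.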